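Two Epimers Level, Their Shared Ring Group Then Replaced

The compounds below may be only part of what the source reports. "The series", "measured", "known", "first", "only" and "open" are said of these compounds alone.

In a functional assay on HL-60 cells (Homo sapiens) for antiproliferative activity, read by XTT assay, with a stated time of 72 h (on this read-out higher numbers stand for weaker inhibition and lower numbers for stronger inhibition), compound 2 `C=C(C)CCC[C@]1(C)C2=CCC[C@](C)(C[C@H](O)C3=CC(=O)OC3O)[C@H]2CC[C@H]1C` gives 3000 nM, within the scatter of compound 1 `C=C(C)CCC[C@]1(C)C2=CCC[C@](C)(C[C@@H](O)C3=CC(=O)OC3O)[C@H]2CC[C@H]1C` at 3200 nM. The next structure, compound 3 `C=C(C)CCC[C@]1(C)C2=CCC[C@](C)(C[C@H](O)c3ccoc3)[C@H]2CC[C@H]1C`, replaces a ring group found in both: a group of 5 heavy atoms (4 carbon, 1 oxygen; one five-membered aromatic ring with 1 hetero atom) in place of a group of 7 heavy atoms (4 carbon, 3 oxygen; one five-membered non-aromatic ring with 1 hetero atom), on a saturated chain carbon bound to an oxygen on a saturated carbon and a saturated chain carbon. Among the measured compounds shown here, the only measured step, a 1.1-fold lower number from compound 1 to compound 2 (0.03 log units; within the scatter), concerns a stereocentre at a saturated chain carbon and leaves that ring group untouched, so it does not size this exchange. A modest loss of inhibition in this assay is tentatively expected, an estimated 2.7-fold higher number from compound 2 to compound 3 (0.43 log units; beyond the scatter). For compound 3, the estimated value is 8000 nM, with an expected range of 2500 nM to 30000 nM.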

Compound 3, half-maximal inhibitory concentration: 31200 nM
Beside the measured number, compound 3's estimate is 3.9-fold (0.59 log units) below it; measured number outside the range, above it.
By their numbers in this assay, from the lowest: compounds 2 and 1 (each within the scatter of the next); then compound 3.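

In this assay, this ring group proves far more consequential than the stereocentre, which had produced no step beyond the scatter: furan-3-yl in its place gives a 10-fold higher number from compound 2 to compound 3 (1.02 log units; beyond the scatter). The comparison with the other epimer gives a step of similar size, a 9.8-fold higher number from compound 1 to compound 3 (0.99 log units; beyond the scatter). Nothing shown explains this loss. The compounds shown leave open which part of the departing ring group matters, and whether a carboxylic acid or a tetrahydrofuran-3-yl group at this place would restore the inhibition.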